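Taking a Long Chain Off an Oxygen, Twice

The compounds below may be only part of what the source reports. "The series", "measured", "known", "first", "only" and "open" are said of these compounds alone.

Of the compounds shown here, three have been measured in a functional assay on HeLa cells (Homo sapiens) for cytotoxicity, read by XTT assay, with a stated time of 72 h; on this read-out higher numbers stand for weaker inhibition and lower numbers for stronger inhibition. Compound 1 `CC(C)=CCC/C=C(\C)Cc1c(O)cc(O)c2c(=O)cc(-c3ccccc3)oc12` gives 19000 nM. Compound 2 `CC(C)=CCC/C=C(\C)Cc1c(O)cc(O)c2c(=O)c(OC/C=C(\C)CCC=C(C)C)c(-c3ccc(O)cc3)oc12` gives 27000 nM. Compound 3 `CC(C)=CCC/C=C(\C)Cc1c(OC/C=C(\C)CCC=C(C)C)cc(O)c2c(=O)cc(-c3ccccc3)oc12` reaches only a limit of the assay, > 100000 nM.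

The change from compound 3 to compound 1 is hydrogen in place of 3,7-dimethylocta-2,6-dien-1-yl on an oxygen on an aromatic ring, and it produced an at least 5.2-fold lower number from compound 3 to compound 1 (0.72 log units; beyond the scatter). That step can be stated only as a bound, since the value of compound 3 is a limit (the limit of > 100000 nM in this assay, at which 1 of the 3 values shown sits).

Compound 4 `CC(C)=CCC/C=C(\C)Cc1c(O)cc(O)c2c(=O)c(O)c(-c3ccc(O)cc3)oc12` is made from compound 2 by the same change, (hydrogen in place of 3,7-dimethylocta-2,6-dien-1-yl on an oxygen on an aromatic ring); the place is identical in both cases. How the cores of compound 2 and compound 3 differ is not broken down here.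

On the strength of the earlier step, compound 4 is expected to show a 5.4-fold lower number from compound 2 to compound 4 (0.73 log units; beyond the scatter), and its estimated value in this assay is 5000 nM, from 1500 nM to 20000 nM.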

Compound 4, half-maximal inhibitory concentration: 30000 nM
For compound 4 the middle estimate is 6.0-fold (0.78 log units) below the measured one; the measured number lies above the stated range.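

On the second core, swapping the 3,7-dimethylocta-2,6-dien-1-yl chain for hydrogen gives a 1.1-fold higher number from compound 2 to compound 4 (0.05 log units; within the scatter) in this assay, so the change did not carry over from one core to the other: the same change on two cores in this assay, an at least 5.2-fold lower number (0.72 log units; beyond the scatter) from compound 3 to compound 1 and a 1.1-fold higher number (0.05 log units; within the scatter) from compound 2 to compound 4, at least 5.8-fold (0.76 log units) apart, beyond the scatter of two such steps

This shows that a step measured on one core in this series cannot simply be transferred to another, but two pairs do not show which difference between the cores matters. Compound 3 gives > 100000 nM, which is a limit of the assay.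

On these data alone, it remains open how a shorter chain on that oxygen, or a chain carrying an amine or a carboxylic acid, would behave on each core.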